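The source may report more compounds than this note shows. Statements on the series, on what has been measured and on what is new or still open speak of the compounds shown alone.

Of the compounds shown here, three built on one shared core have been tested in a functional assay on A-431 cells (Homo sapiens) for inhibition, read by MTT assay, with a stated time of 72 h; on this read-out higher numbers stand for weaker inhibition and lower numbers for stronger inhibition: compound 1 `Clc1ccc(-c2nnc(SCCCN3CCN(c4nc5ccccc5o4)CC3)o2)cc1`, compound 2 `Brc1ccc(-c2nnc(SCCCN3CCN(c4nc5ccccc5o4)CC3)o2)cc1` and compound 3 `c1ccc(-c2nnc(SCCCN3CCN(c4nc5ccccc5o4)CC3)o2)cc1`. Here compound 1 gives 89600 nM, compound 2 gives 57800 nM and compound 3 gives 57600 nM, so compound 2 stands within the scatter of the other two. The untested compound 4 `Brc1ccc(-c2nnc(SCCCN3CCN(c4nc5ccccc5s4)CC3)o2)cc1` keeps the bromo group of compound 2 but carries 1,3-benzothiazol-2-yl in place of 1,3-benzoxazol-2-yl on an amine nitrogen in a ring. Within the data shown here, no measured step involves this group. Among the measured compounds shown here, the only guides are swaps on an aromatic carbon, namely a 1.6-fold lower number from compound 1 to compound 2 (0.19 log units; within the scatter), a 1.6-fold lower number from compound 1 to compound 3 (0.19 log units; within the scatter) and a 1.0-fold lower number from compound 2 to compound 3 (0.00 log units; within the scatter). These steps concern a different place and say little about the new change, so no step beyond the scatter is expected in this assay, in either direction. The estimated step is a 1.2-fold lower number from compound 2 to compound 4 (0.06 log units; within the scatter). For compound 4 the estimate is 50000 nM, with an expected range from 20000 nM to 110000 nM.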

Compound 4, half-maximal inhibitory concentration: 51600 nM
Beside the measured number, compound 4's estimate is 1.0-fold (0.01 log units) below it; the range from low to high includes it.
By their numbers in this assay, from the lowest: compounds 4, 3, 2 and 1 (each within the scatter of the next).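

In this assay, 1,3-benzothiazol-2-yl in place of 1,3-benzoxazol-2-yl on the amine nitrogen in a ring gives a 1.1-fold lower number from compound 2 to compound 4 (0.05 log units; within the scatter), so exchanging the oxygen of this group for sulfur leaves the read-out within the scatter. Among these compounds, the earlier compounds differed only on an aromatic carbon, so this is the first view of a change at the ring amine nitrogen, and with the bromo group held constant, this exchange makes no clear difference there. Nothing shown gives a reason for this result.

From the compounds shown here alone, it remains open whether a more different group on that nitrogen, such as a plain phenyl ring or a benzyl group, would produce a step beyond the scatter. Going by these compounds, it is also open whether the same exchange would behave alike with chloro or hydrogen on the aromatic carbon.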